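The source may report more compounds than this note shows. Statements on the series, on what has been measured and on what is new or still open speak of the compounds shown alone.

In an ADME assay on CEM-SS cells (Homo sapiens) for cytotoxicity, read by XTT assay, with a stated time of 6 days (a higher number here means that more compound is tolerated, a lower number that less compound is tolerated), compound 1 `CCCC(=O)OCSc1ccccc1C(=O)NCC(N)=O` gives > 100 uM, which is a limit of the assay and not a number. Compound 1 thus stands at the limit of > 100 uM in this assay, at which 1 of the 3 values shown sits. Among the measured compounds shown here, compound 2 `CCCC(=O)OCSc1ccccc1C(=O)NCCCC(N)=O` gives 56.6 uM, and compound 3 `CCCC(=O)OCSc1ccccc1C(=O)NCCCNC(C)=O` gives 21.1 uM, the lowest number so far. The measured steps are an at least 1.7-fold lower number from compound 1 to compound 2 (0.24 log units; that floor lies within the scatter), an at least 4.7-fold lower number from compound 1 to compound 3 (0.67 log units; beyond the scatter) and a 2.7-fold lower number from compound 2 to compound 3 (0.43 log units; beyond the scatter).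

Compound 4 `CCCC(=O)OCSc1ccccc1C(=O)OCC(N)=O` differs from compound 3 as follows: carbamoylmethoxy in place of (3-acetamidopropyl)amino on a carbonyl carbon. Thus carbamoylmethoxy takes the place of (3-acetamidopropyl)amino on a carbonyl carbon. For the measured compounds named here, no measured step replaces the amide-type nitrogen with an oxygen, so the guide is only partial. The closest evidence is a 2.7-fold lower number from compound 2 to compound 3 (0.43 log units; beyond the scatter), since compound 4 loses the acetamido group of compound 3 and carries a carbamoyl group, as compound 2 does. Read in reverse, that step points to a modest rise in the tolerated concentration, and an at least 4.7-fold lower number from compound 1 to compound 3 (0.67 log units; beyond the scatter) points the same way. The expected change is a 2.1-fold higher number from compound 3 to compound 4 (0.33 log units; beyond the scatter). For compound 4 the estimated value is 45 uM, with an expected range from 15 uM to 100 uM.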

Compound 4, half-maximal toxic concentration: 82.1 uM
Compound 4: middle estimate off by 1.8-fold (0.26 log units), on the low side; the range from low to high includes it.
By their numbers in this assay, from the lowest: compound 3; then compounds 2 and 4 (each within the scatter of the next). At a limit, above all of these: compound 1.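

In this assay, among the compounds shown here, carbamoylmethoxy in place of (3-acetamidopropyl)amino on a carbonyl carbon gives a 3.9-fold higher number from compound 3 to compound 4 (0.59 log units; beyond the scatter), the first step to show that this carbonyl carbon tolerates an oxygen-linked group in place of an amide-type nitrogen and that such a change can lift the number beyond the scatter. Against the carbamoyl-ended amide, the same kind of change gives a 1.5-fold higher number from compound 2 to compound 4 (0.16 log units; within the scatter), so carbamoylmethoxy and (3-carbamoylpropyl)amino cannot be told apart here. With (carbamoylmethyl)amino as the group replaced, the change gives an at least 1.2-fold lower number from compound 1 to compound 4 (0.08 log units; that floor lies within the scatter), which is only a floor and sets no order, the starting value being a limit and not a number: the limit of > 100 uM in this assay, at which 1 of the 4 values shown sits.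

The compounds shown leave open how an ester ending in an acetamido group would read, which would separate the linking oxygen from the chain end. As far as these compounds go, how a carboxylic acid or an amine at the chain end would read in this assay also stays open.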